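The compounds below may be only part of what the source reports. "The series", "measured", "known", "first", "only" and "open" are said of these compounds alone.

In a functional assay on HepG2 cells (Homo sapiens) for antiproliferative activity, read by sulforhodamine B assay, with a stated time of 72 h (on this read-out higher numbers stand for weaker inhibition and lower numbers for stronger inhibition), the measured compounds stand as follows:

Compound 1 `O=C(Cn1nc(-c2ccccc2)c2ccccc2c1=O)Nc1ccccc1` gives 13400 nM
Compound 2 `O=C(Cn1nc(-c2ccccc2)c2ccccc2c1=O)Nc1cccc(Cl)c1` gives 3290 nM

Compound 2 stands lowest of the two, at 3290 nM against the higher number of compound 1. The next compound is compound 3 `O=C(Cn1nc(-c2ccccc2)c2ccccc2c1=O)Nc1ccc(Cl)cc1`, which has not yet been measured. The change to it reads 4-chlorophenyl in place of 3-chlorophenyl on an amide-type nitrogen and so places 4-chlorophenyl in place of 3-chlorophenyl on an amide-type nitrogen, with the same atoms joined differently.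

Among the measured compounds shown here, one measured step bears on this. It is a 4.1-fold lower number from compound 1 to compound 2 (0.61 log units; beyond the scatter) for chloro in place of hydrogen on an aromatic carbon, a modest step beyond the scatter. For the measured compounds named here, compound 3 also carries a chlorine, but no measured step exchanges one chlorophenyl for the other, so neither direction is favoured. The expected size is a 1.2-fold higher number from compound 2 to compound 3 (0.08 log units; within the scatter) in this assay and this estimate means no step beyond the scatter. Compound 3 is estimated at 4000 nM in this assay with an expected range from 1400 nM to 11000 nM for its measurement.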

Compound 3, half-maximal inhibitory concentration: 10300 nM
The estimate for compound 3 lay 2.6-fold (0.41 log units) below the measured number; the measured number falls inside the stated range.
By their numbers in this assay, from the lowest: compound 2; then compounds 3 and 1 (each within the scatter of the next).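

In this assay, exchanging the 3-chlorophenyl group on the amide-type nitrogen for 4-chlorophenyl gives a 3.1-fold higher number from compound 2 to compound 3 (0.50 log units; beyond the scatter), so two groups with the same atoms, joined differently, do not read alike in this series. The presence of chlorine alone therefore does not go with a lower number: the step for chloro in place of hydrogen that leads to the 4-chlorophenyl group gives a 1.3-fold lower number from compound 1 to compound 3 (0.11 log units; within the scatter), which lies within the scatter, whereas the 3-chlorophenyl group of compound 2 stands beyond the scatter from both other compounds. Nothing at hand explains why the two chlorophenyl groups differ.

The three compounds leave open whether this dependence on where the chlorine sits is particular to chlorine or would also appear with fluoro, methoxy or an amine on the same phenyl ring. They also leave open whether the difference between 3-chlorophenyl and 4-chlorophenyl would persist on a core carrying a different group in place of its phenyl substituent, or in cells other than those of this one assay.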